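This account rests on a few compounds, and the source may have more. Where it says the series, first, only, none or still open, it means among the compounds named here.

In a physicochemical assay for acid dissociation, three compounds have numbers. Compound 1 `COc1ccc(F)cc1CNCCCNc1ccnc2cc(Cc3cc(C)cc(C)c3)ccc12` gives 9.47, compound 2 `Fc1ccc(Oc2ccc3c(NCCCNCc4ccco4)ccnc3c2)cc1` gives 9.28, and compound 3 `Fc1ccc(Cc2ccc3c(NCCCNCc4ccco4)ccnc3c2)c(Cl)c1` gives 9.47. Compound 3 stands level with compound 1 at the digits shown, the two together the highest of the three, and its only gap is to compound 2, within the scatter. Among the measured compounds shown here, the single measured step, a number 0.19 log units higher from compound 2 to compound 3 (within the scatter), is the only guide. Compound 4 `Cc1cc(C)cc(Cc2ccc3c(NCCCNCc4ccco4)ccnc3c2)c1` differs from compound 3 by 3,5-dimethylphenyl in place of 2-chloro-4-fluorophenyl on a saturated chain carbon bound to an aromatic carbon. This change sits at the same part of the molecule as the step into compound 3, which stayed within the scatter, and compound 1, which bears the same 3,5-dimethylbenzyl on the shared core, gives 9.47. Compound 4 is therefore expected to show no step beyond the scatter, a number 0.02 log units lower from compound 3 to compound 4 (within the scatter). The estimated value of compound 4 is 9.45, within 9.2 to 9.7.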

Compound 4, acid dissociation constant: 9.47
Beside the measured number, compound 4's estimate is 0.02 log units below it; the measured number falls inside the stated range.
By their numbers in this assay, from the lowest: compounds 2, 1, 3 and 4 (each within the scatter of the next).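

In this assay, 3,5-dimethylphenyl in place of 2-chloro-4-fluorophenyl gives no change at the digits printed from compound 3 to compound 4 (within the scatter), and 3,5-dimethylbenzyl in place of 4-fluorophenoxy gives a number 0.19 log units higher from compound 2 to compound 4 (within the scatter), so two further changes at this place stay within the scatter. A second place is now also covered: furan-2-yl in place of 5-fluoro-2-methoxyphenyl on a saturated chain carbon bound to an amine nitrogen gives no change at the digits printed from compound 1 to compound 4 (within the scatter). No measurement shown offers an explanation for these results. As far as these compounds go, it remains open whether an amine or a carboxylic acid at either place would give a step beyond the scatter.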